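A few compounds are considered here, and "the series" means these few. Any claim that something is new, unique, unknown or untested is made for them only; others in the source may bear on it.

The series is followed in a functional assay on NCI-H322M cells (Homo sapiens) for inhibition, read by sulforhodamine B assay, with a stated time of 48 h; a higher number here means that more compound is tolerated, a lower number that less compound is tolerated. Compound 1 `Nc1cc(N)c2nc(-c3ccccc3)c(NCc3ccc(Cl)c(Cl)c3)nc2c1` gives 69200 nM in this assay, and this is the only plain number shown. Compound 2 `CCOC(=O)[C@H](CCC(=O)O)NC(=O)c1ccc(Sc2nc3cc(N)cc(N)c3nc2-c2ccccc2)cc1` reaches only the assay limit in this assay, < 100000 nM. Among the values shown, (the limit of < 100000 nM in this assay, at which 1 of the 2 values shown sits), so compound 1 stands alone as a measured figure. Compound 3 `Nc1cc(N)c2nc(-c3ccccc3)c(NCc3ccc(F)cc3)nc2c1` is not yet measured; it differs from compound 1 in one place, (4-fluorophenyl in place of 3,4-dichlorophenyl on a saturated chain carbon bound to a nitrogen on an aromatic ring). Going by the values given here, no step between two measured compounds is available to guide the size of this change, so the expectation rests on the single figure for compound 1. The step expected in this assay is a 1.2-fold higher number from compound 1 to compound 3 (0.06 log units; within the scatter), judged to be none beyond the usual scatter or at most a small move toward a more tolerated compound. Compound 3 is therefore estimated at 80000 nM in this assay, with a likely range from 35000 nM to 180000 nM.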

Compound 3, concentration lethal to 50% of the cells: 40700 nM
Compound 3: the middle estimate sits 2.0-fold (0.29 log units) above what was measured, and the stated range covers the measured number.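

In this assay, going by these compounds alone, the first step at this position is a 1.7-fold lower number from compound 1 to compound 3 (0.23 log units; within the scatter), so compound 1 and compound 3 cannot be told apart on this read-out. On a saturated chain carbon bound to a nitrogen on an aromatic ring, 3,4-dichlorobenzyl and 4-fluorobenzyl therefore give values within the scatter of each other, at least in this one pair. Nothing measured here bears on why the two compounds fall so close together.

The compounds shown leave open whether an unsubstituted phenyl, a longer chain to the ring, or an amine or carboxylic acid on that ring would move the number beyond the scatter. A single pair also cannot separate the kind of halogen from the number of halogens on the ring.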